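Removing the methoxy from the phenyl ring of compound 1

A few compounds are considered here, and "the series" means these few. Any claim that something is new, unique, unknown or untested is made for them only; others in the source may bear on it.

Measured compounds: compound 1 `COC(=O)c1sc2ccccc2c1C#Cc1ccc(OC)cc1`, 90600 nM; compound 2 `COC(=O)c1sc2cc(OC)ccc2c1C#Cc1ccc(F)cc1`, 12600 nM; compound 3 `COC(=O)c1sc2cc(OC)ccc2c1C#Cc1ccccc1F`, 11400 nM.

In a functional assay on MCF7 cells (Homo sapiens) for cytotoxicity, read by sulforhodamine B assay, with a stated time of 48 h (on this read-out higher numbers stand for weaker inhibition of growth and lower numbers for stronger inhibition of growth), compound 1 stands highest of the three numbers, with compound 2 and compound 3 both well beyond the scatter below it. Compound 4 `COC(=O)c1sc2ccccc2c1C#Cc1ccccc1` differs from compound 1 by a single change: hydrogen in place of methoxy on an aromatic carbon. Among the measured compounds shown here, no measured step shares this change. The only step shown, a 1.1-fold lower number from compound 2 to compound 3 (0.04 log units; within the scatter), concerns the position of a fluorine and not a methoxy, and it lay within the scatter. Nothing in the data therefore points to a shift in this assay, and compound 4 is expected to lie near compound 1, so that a 1.1-fold lower number from compound 1 to compound 4 (0.03 log units; within the scatter) is estimated. Compound 4 is estimated at 85000 nM, between 25000 nM and 250000 nM.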

Compound 4, concentration for 50% growth inhibition: 71600 nM
Compound 4: middle estimate off by 1.2-fold (0.07 log units), on the high side; low and high end bracket the measured number.
By their numbers in this assay, from the lowest: compounds 3 and 2 (each within the scatter of the next); then compounds 4 and 1 (each within the scatter of the next).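

In this assay the step is a 1.3-fold lower number from compound 1 to compound 4 (0.10 log units; within the scatter), so on the core of compound 1 a methoxy on an aromatic carbon, para to a large group, can give way to hydrogen with no shift beyond the scatter. Among the compounds shown here, this is the first reading of a change of group at this position, since the earlier step concerned only where a fluorine sat. Nothing available bears on this result. On these data alone, whether an amine or a carboxylic acid at this place would leave the number as unmoved remains open, as does whether hydrogen in place of a group here behaves alike on the core of compound 2.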